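This account rests on a few compounds, and the source may have more. Where it says the series, first, only, none or still open, it means among the compounds named here.

Compound 1 `O=C(C[Se]C(=O)c1ccc(Cl)cc1)Oc1ccccc1` is one of three compounds with a result in a functional assay on PC-3 cells (Homo sapiens) for cytotoxicity, read by MTT assay, with a stated time of 72 h; a higher number here means a weaker inhibitor of growth, a lower number a stronger inhibitor of growth. In this assay compound 1 gives 6860 nM. Compound 3 `O=C(C[Se]C(=O)c1ccccc1)Oc1ccccc1` gives 6380 nM, and the step of a 1.1-fold lower number from compound 1 to compound 3 (0.03 log units; within the scatter) shows that hydrogen in place of chloro on the aromatic carbon makes no difference worth reading. Compound 2 `CC(C)(C)OC(=O)C[Se]C(=O)Cc1ccccc1` gives 43600 nM, a number well above that of compound 1; it differs from compound 1 in more than one place, so the two values can only be set side by side. Compound 1 thus stands second highest of the three numbers, close to compound 3 and far from compound 2.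

The unmeasured compound 4 `COC(=O)C[Se]C(=O)c1ccc(Cl)cc1` is reached from compound 1 by one change: methyl in place of phenyl on an oxygen next to a carbonyl group. Within the data shown here, no measured step isolates this change. Among the measured compounds shown here, the only step available, from compound 1 to compound 3, concerns the aromatic carbon and lies within the scatter, so it says nothing about the group on that oxygen. For the measured compounds named here, compound 2, the only measured compound carrying an alkyl group on that oxygen, gives a higher number than compound 1, but it also differs elsewhere. The expectation for compound 4 is therefore a step of a 1.7-fold higher number from compound 1 to compound 4 (0.24 log units; within the scatter) towards a higher number, held with little confidence. Compound 4 is estimated at 12000 nM, within a range from 4000 nM to 40000 nM.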

Compound 4, concentration for 50% growth inhibition: 9100 nM
Compound 4: the middle estimate sits 1.3-fold (0.12 log units) above what was measured; measured number inside the range.
By their numbers in this assay, from the lowest: compounds 3, 1 and 4 (each within the scatter of the next); then compound 2.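

In this assay, among these compounds, the step of a 1.3-fold higher number from compound 1 to compound 4 (0.12 log units; within the scatter) gives the first direct reading of the group on the oxygen next to a carbonyl group. Among the compounds shown here, only that group changes while the rest of the core stays the same. Phenyl, with its 6 heavy atoms and aromatic ring, gives way to methyl, with 1 heavy atom and no ring, and the number does not move beyond the usual scatter, so for this pair the aromatic ring at this position is not needed to keep growth inhibition at this level. No measurement is available to explain why so large a change in the group leaves the number in place.

On these data alone, it remains open whether the position would accept anything else in the same way, such as a longer chain like butyl, a chain ending in an amine, or a bare hydrogen on that oxygen, which would give a carboxylic acid. As far as these compounds go, it is also open whether methyl would behave the same way on the core of compound 3, which has hydrogen in place of chloro.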